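Changing the amide group on a weak inhibitor

The source may hold more compounds than are shown below. What is called first, only, known or untested is meant among the compounds shown, and "the series" means these compounds.

Measured so far in a functional assay on MIA PaCa-2 cells (Homo sapiens) for inhibition, read by MTT assay; on this read-out higher numbers stand for weaker inhibition and lower numbers for stronger inhibition:
compound 1 `CCC(CO)Nc1ncc2cc(C(=O)N(C)C)n(C3CCCC3)c2n1` gives 31000 nM
compound 2 `CN(C)C(=O)c1cc2cnc(Nc3cccnc3)nc2n1C1CCCC1` gives 26000 nM
compound 3 `O=C(c1cc2cnc(Nc3ccc(N4CCNCC4)cn3)nc2n1C1CCCC1)N1CCCCC1` gives 39600 nM

Compound 3, at 39600 nM, lies within the usual scatter of repeated measurements of both other compounds, so no order can be read among the three.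

The next compound is compound 4 `COc1ccccc1NC(=O)c1cc2cnc(Nc3ccc(N4CCNCC4)cn3)nc2n1C1CCCC1`, which differs from compound 3 in one place: (2-methoxyphenyl)amino in place of piperidin-1-yl on a carbonyl carbon. In words, (2-methoxyphenyl)amino stands in place of piperidin-1-yl on a carbonyl carbon.

Among the compounds with values here, only one measured step can serve as a guide, and it is a loose one. It is a 1.2-fold lower number from compound 1 to compound 2 (0.08 log units; within the scatter), with pyridin-3-yl in place of 1-(hydroxymethyl)propyl on a nitrogen on an aromatic ring. That change sits elsewhere on the molecule and stayed within the scatter. Within the data shown here, no measured step changes the group on the carbonyl carbon, so the effect of this swap is untested and the range must stay wide.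

In this assay no shift beyond the scatter is expected, and the estimated step is a 1.4-fold lower number from compound 3 to compound 4 (0.15 log units; within the scatter). Compound 4 is therefore estimated at 28000 nM, with an expected range of 8000 nM to 60000 nM.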

Compound 4, half-maximal inhibitory concentration: 1830 nM
Estimate against measurement, compound 4: 15-fold (1.18 log units) above; the whole stated range lies above it.
By their numbers in this assay, from the lowest: compound 4; then compounds 2, 1 and 3 (each within the scatter of the next).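

In this assay, the group on the carbonyl carbon proves able to move the number well beyond the scatter: putting (2-methoxyphenyl)amino in place of piperidin-1-yl gives a 22-fold lower number from compound 3 to compound 4 (1.34 log units; beyond the scatter), and here a lower number means stronger inhibition. The only earlier step, a 1.2-fold lower number from compound 1 to compound 2 (0.08 log units; within the scatter), changed a group on a nitrogen on an aromatic ring and stayed within the scatter, so this is the first single change among these compounds to produce a clear difference. The swap alters several things at once, replacing a six-membered non-aromatic ring with a six-membered aromatic ring of carbon only and adding a hydrogen-bond donor and a hydrogen-bond acceptor, and nothing measured here ties the stronger inhibition to any one of these.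

The compounds shown leave open whether the methoxy group, the aromatic ring or the amide hydrogen carries the step, and a plain phenylamino group or a benzylamino group on the same carbonyl carbon would help separate these. Going by these compounds, it also remains open whether the step would hold with a different group on the nitrogen on the aromatic ring, such as the pyridin-3-yl of compound 2.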